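This account rests on a few compounds, and the source may have more. Where it says the series, first, only, none or still open, it means among the compounds named here.

Measured in a functional assay on HeLa cells (Homo sapiens) for cytotoxicity, read by MTT assay, with a stated time of 48 h; a lower number here means a stronger inhibitor, a higher number a weaker inhibitor:

- compound 1 `CC1(C)CCC[C@]2(C)[C@@H](CC[C@@](C)(O)/C=C/c3ccccc3)[C@](C)(O)CC[C@@H]12`: 3320 nM
- compound 2 `CC1(C)CCC[C@]2(C)[C@@H](CC[C@@](C)(O)/C=C/c3cccc([N+](=O)[O-])c3)[C@](C)(O)CC[C@@H]12`: 3380 nM
- compound 3 `CC1(C)CCC[C@]2(C)[C@@H](CC[C@@](C)(O)/C=C/c3ccc(Cl)nc3)[C@](C)(O)CC[C@@H]12`: 3680 nM

These compounds share one core and differ only in the aromatic group at the end of the chain. Compound 3, at 3680 nM, cannot be told apart from the other two. Its value lies within the usual scatter of theirs.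

The next compound, compound 4 `Cc1cccc(C)c1/C=C/[C@](C)(O)CC[C@@H]1[C@@]2(C)CCCC(C)(C)[C@@H]2CC[C@@]1(C)O`, carries a new aromatic group: 2,6-dimethylphenyl in place of 6-chloropyridin-3-yl on a double-bonded chain carbon bound to a double-bonded chain carbon. In words, 2,6-dimethylphenyl takes the place of 6-chloropyridin-3-yl on a double-bonded chain carbon bound to a double-bonded chain carbon.

Among the measured compounds shown here, three measured steps bear on this change. Adding a nitro group gave a 1.0-fold higher number from compound 1 to compound 2 (0.01 log units; within the scatter). Exchanging whole aromatic groups gave a 1.1-fold higher number from compound 1 to compound 3 (0.04 log units; within the scatter) and a 1.1-fold higher number from compound 2 to compound 3 (0.04 log units; within the scatter). All of these steps are small, so in this assay no step beyond the scatter is expected. For the measured compounds named here, none of the measured compounds carries a 2,6-dimethylphenyl group, however, so this expectation is an extrapolation and the range is kept wide.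

The expected change is a 1.1-fold lower number from compound 3 to compound 4 (0.02 log units; within the scatter). The estimate for compound 4 is 3500 nM, with an expected range from 1700 nM to 7000 nM.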

Compound 4, half-maximal inhibitory concentration: 3460 nM
For compound 4 the middle estimate is 1.0-fold (0.00 log units) above the measured one, within the range that was stated.
By their numbers in this assay, from the lowest: compounds 1, 2, 4 and 3 (each within the scatter of the next).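

In this assay, the 2,6-dimethylphenyl group on a double-bonded chain carbon bound to a double-bonded chain carbon gives a 1.1-fold lower number from compound 3 to compound 4 (0.03 log units; within the scatter), as well as a 1.0-fold higher number from compound 2 to compound 4 (0.01 log units; within the scatter) and a 1.0-fold higher number from compound 1 to compound 4 (0.02 log units; within the scatter), so it cannot be told apart from any of the three earlier groups. The earlier compounds had shown this only for phenyl, 3-nitrophenyl and 6-chloropyridin-3-yl; compound 4 extends it to a ring of carbon only that enters in place of a ring with a hetero atom, and the chlorine and the hydrogen-bond acceptor counted on the leaving group go with the change, with no step beyond the scatter. What lies behind this flat result cannot be said, as nothing measured here speaks to it.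

All four compounds keep the same core and an aromatic ring at the end of the chain, which leaves open whether an amine, a carboxylic acid or a longer chain at this place would also stay within the scatter. From the compounds shown here alone, the hydroxyl groups are likewise shared by all four compounds, and what they contribute to the cytotoxicity remains open.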